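The source may report more compounds than this note shows. Statements on the series, on what has been measured and on what is new or still open speak of the compounds shown alone.

Working notes on the series, read in a functional assay on DU-145 cells (Homo sapiens) for inhibition, read by trypan blue exclusion, with a stated time of 96 h; a higher number here means a weaker inhibitor of growth, a lower number a stronger inhibitor of growth. Compound 1 (`CN(C)c1ccc(/C=C(/SCc2ccccc2Cl)C(=O)c2ccc(Cl)cc2)cc1`) gives > 100000 nM, which is a limit of the assay and not a number. Going by the values given here, compound 2 (`O=C(/C(=C\c1ccccc1F)S(=O)(=O)c1ccc(Br)cc1)c1ccc(Cl)cc1`) gives 25000 nM, and compound 3 (`COc1ccccc1/C=C(\C(=O)c1ccc(Cl)cc1)S(=O)(=O)c1ccc(Br)cc1`) gives 10000 nM, the lower of the two numbers measured so far. Compound 4 (`CN(C)c1ccc(/C=C(\C(=O)c2ccc(Cl)cc2)S(=O)(=O)c2ccc(Br)cc2)cc1`) is the next structure, and the change is 4-(dimethylamino)phenyl in place of 2-methoxyphenyl on a double-bonded chain carbon bound to a double-bonded chain carbon. Among the compounds with values here, the only measured step that bears on it is a 2.5-fold lower number from compound 2 to compound 3 (0.40 log units; beyond the scatter), which is modest and beyond the scatter. Compound 1 also carries 4-(dimethylamino)phenyl but differs from compound 4 elsewhere, so the limit of > 100000 nM in this assay, at which 1 of the 3 values shown sits, gives no step size, only a reason to keep the upper end of the range wide. In this assay the expected step is a 1.5-fold higher number from compound 3 to compound 4 (0.18 log units; within the scatter), which is not expected to go beyond the scatter. For compound 4 the estimated value is 15000 nM, with an expected range of 4000 nM to 60000 nM.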

Compound 4, concentration for 50% growth inhibition: > 100000 nM
Compound 4 was reported as a limit; the forecaster's own chance of this, stated with the estimate: 15%; middle value at least 6.6-fold (0.82 log units) from the limit.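

In this assay, this carbon proves far less forgiving than methoxy in place of fluoro suggested, which gave a 2.5-fold lower number from compound 2 to compound 3 (0.40 log units; beyond the scatter). With 4-(dimethylamino)phenyl on it, the series gives an at least 10-fold higher number from compound 3 to compound 4 (1.00 log units; beyond the scatter), and also an at least 4.0-fold higher number from compound 2 to compound 4 (0.60 log units; beyond the scatter), so the aryl group here can move growth inhibition well beyond the scatter. The value of compound 4 is a limit of the assay and not a number, so these steps are lower bounds, and the step between compound 1 and compound 4, which both carry 4-(dimethylamino)phenyl, cannot be read: the limit of > 100000 nM in this assay, at which 2 of the 4 values shown sit.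

The compounds shown do not separate the dimethylamino group from its place on the ring. Going by these compounds, how a 4-methoxyphenyl or a 2-(dimethylamino)phenyl on this carbon would read in this assay remains open.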